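Trading the amine-bearing chain for an amino acid

The source may hold more compounds than are shown below. What is called first, only, known or untested is meant among the compounds shown, and "the series" means these compounds.

Compound 2 `CCN(CC)CCNC(=O)c1ccc(C(CC)(CC)c2ccc(OCCC(O)(CC)CC)c(C)c2)n1CC` stands highest of the two numbers in a functional assay on Caco-2 cells (Homo sapiens) for antiproliferative activity, read by MTT assay, with a stated time of 48 h (a higher number here means a weaker inhibitor, a lower number a stronger inhibitor), giving 1630 nM, while compound 1 `CCn1c(C(=O)NCCCN(C)C)ccc1C(CC)(CC)c1ccc(OCCC(O)(CC)CC)c(C)c1` gives 490 nM; the step is a 3.3-fold higher number from compound 1 to compound 2 (0.52 log units; beyond the scatter). Compound 3 `CCn1c(C(=O)Nc2ccc(OC(F)(F)F)cc2)ccc1C(CC)(CC)c1ccc(OCCC(O)(CC)CC)c(C)c1` reaches only a limit in this assay, > 50000 nM (the limit of > 50000 nM in this assay, at which 1 of the 3 values shown sits). The steps of an at least 100-fold higher number from compound 1 to compound 3 (2.00 log units; beyond the scatter) and an at least 30-fold higher number from compound 2 to compound 3 (1.48 log units; beyond the scatter) are both large. Compound 4 `CCC(C)C(NC(=O)c1ccc(C(CC)(CC)c2ccc(OCCC(O)(CC)CC)c(C)c2)n1CC)C(=O)O` differs from compound 2 in one place: 1-carboxy-2-methylbutyl in place of 2-(diethylamino)ethyl on an amide-type nitrogen. The step that bears most on it is an at least 30-fold higher number from compound 2 to compound 3 (1.48 log units; beyond the scatter), where the 2-(diethylamino)ethyl also leaves the amide-type nitrogen; the smaller 3.3-fold higher number from compound 1 to compound 2 (0.52 log units; beyond the scatter) is a change of a different kind. A large rise is therefore expected for compound 4, a 9.2-fold higher number from compound 2 to compound 4 (0.96 log units; beyond the scatter). Compound 4 is estimated at 15000 nM, between 4000 nM and 50000 nM.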

Compound 4, half-maximal inhibitory concentration: 20000 nM
Compound 4: middle estimate off by 1.3-fold (0.12 log units), on the low side; the measured number falls inside the stated range.
By their numbers in this assay, from the lowest: compound 1; then compound 2; then compound 4. At a limit, above all of these: compound 3.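

At the amide-type nitrogen, a chain with no ring and no amine, 1-carboxy-2-methylbutyl, also costs much in this assay: a 12-fold higher number from compound 2 to compound 4 (1.09 log units; beyond the scatter) and a 41-fold higher number from compound 1 to compound 4 (1.61 log units; beyond the scatter), so the earlier loss with 4-(trifluoromethoxy)phenyl is not peculiar to a ring-bearing group. Even so, 1-carboxy-2-methylbutyl fares better than that group, with an at least 2.5-fold lower number from compound 3 to compound 4 (0.39 log units; beyond the scatter). This step rests on compound 3, whose value is a limit and not a number: the limit of > 50000 nM in this assay, at which 1 of the 4 values shown sits.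

The compounds shown leave open whether the loss follows the carboxylic acid or the missing amine. A methyl ester in place of the acid, or a chain bearing both an amine and a carboxylic acid, would separate the two.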